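Permeability notes: furan swap on the amine arm

The source may report more compounds than this note shows. Statements on the series, on what has been measured and on what is new or still open speak of the compounds shown alone.

Three compounds of the series have numbers in an ADME assay for permeability, using PAMPA, with a stated time of 30 min, at pH 7.4; on this read-out lower numbers stand for lower permeability and higher numbers for higher permeability. Compound 1 `Fc1ccc(-c2ccc3c(NCCCNCc4ccco4)ccnc3c2)cc1` gives 237 10^-6 cm/s in this assay. Compound 2 `CC(C)Cc1ccc2c(NCCCNCc3ccco3)ccnc2c1` gives 23 10^-6 cm/s. Compound 3 `COc1cccc(Oc2ccc3c(NCCCNCc4cc(F)ccc4OC)ccnc3c2)c1` gives 317 10^-6 cm/s, the highest of the three numbers; compound 1 lies within the usual scatter of it, while compound 2 sits well away from it, beyond the scatter. Among the compounds with values here, the one single-point step measured so far is a 10-fold lower number from compound 1 to compound 2 (1.01 log units; beyond the scatter), a change on the shared core rather than on the amine arm.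

Compound 4 `COc1cccc(Oc2ccc3c(NCCCNCc4ccco4)ccnc3c2)c1` is not yet measured in this assay. It differs from compound 3 in one place: furan-2-yl in place of 5-fluoro-2-methoxyphenyl on a saturated chain carbon bound to an amine nitrogen. Within the data shown here, no measured step covers this change directly. Among the measured compounds shown here, compound 1 carries the same (furan-2-yl)methyl group on the amine nitrogen together with a different group on the core, and its number in this assay sits within scatter of the number of compound 3, which is the only guide available. On that basis a step of a 1.3-fold lower number from compound 3 to compound 4 (0.10 log units; within the scatter) is expected, none beyond the scatter. The estimate for compound 4 in this assay is 250 10^-6 cm/s, with an expected range from 120 10^-6 cm/s to 450 10^-6 cm/s.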

Compound 4, apparent permeability: 317 10^-6 cm/s
Compound 4: middle estimate off by 1.3-fold (0.10 log units), on the low side, and the stated range covers the measured number.
By their numbers in this assay, from the lowest: compound 2; then compounds 1, 3 and 4 (each within the scatter of the next).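

Within the data shown here, on the saturated chain carbon bound to an amine nitrogen, a ring of nine heavy atoms gives way to one of five, furan-2-yl for 5-fluoro-2-methoxyphenyl, and this assay reads this as the only single-place step on the amine arm in this set (no change at the digits printed from compound 3 to compound 4 (within the scatter)). Among these compounds, with the furan-2-yl arm held constant, the aromatic carbon of the core now offers two further comparisons: 3-methoxyphenoxy in place of isobutyl (a 14-fold higher number from compound 2 to compound 4 (1.14 log units; beyond the scatter)) and 3-methoxyphenoxy in place of 4-fluorophenyl (a 1.3-fold higher number from compound 1 to compound 4 (0.13 log units; within the scatter)), so among compounds 1, 2 and 4 only the isobutyl group of compound 2 stands apart, with no compound going against this in so small a set. No measurement on hand accounts for either the flat arm step or the large core step.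

From the compounds shown here alone, the arm exchange is read only with 3-methoxyphenoxy on the core, so its outcome with isobutyl there remains open. Also open, going by these compounds, is whether an arm ending in a piperidine or a carboxylic acid would stay within the scatter of these numbers.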